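This account rests on a few compounds, and the source may have more. Where it says the series, first, only, none or still open, it means among the compounds named here.

Three compounds share one core and differ only in the group on the aromatic ring. Compound 1 `O=C(O)CNC(=O)COc1ccc([C@H]2CC[C@]3(CC2)OOC2(O3)C3CC4CC(C3)CC2C4)cc1` carries ((carboxymethyl)carbamoyl)methoxy; in a physicochemical assay for solubility, read by nephelometry, measured as kinetic solubility, with a stated time of 30 min, at pH 2.0 (a lower number here means a less soluble compound, a higher number a more soluble compound), compound 1 gives only a limit, < 3.1 ug/mL. Compound 2 `O=C(O)COc1ccc([C@H]2CC[C@]3(CC2)OOC2(O3)C3CC4CC(C3)CC2C4)cc1` carries carboxymethoxy, and in this assay compound 2 gives 6.3 ug/mL. Compound 3 `O=C(O)c1ccc([C@H]2CC[C@]3(CC2)OOC2(O3)C3CC4CC(C3)CC2C4)cc1` carries carboxy; in this assay compound 3 gives only a limit, < 1.6 ug/mL. Compound 3 thus sits at the lower of the two limits shown, (the limit of < 1.6 ug/mL in this assay, at which 1 of the 3 values shown sits). The other limit shown is the limit of < 3.1 ug/mL in this assay, at which 1 of the 3 values shown sits. The measured steps were an at least 2.0-fold higher number from compound 1 to compound 2 (0.30 log units; that floor lies within the scatter), an at least 3.9-fold lower number from compound 2 to compound 3 (0.59 log units; beyond the scatter) and a step that the two limits leave unreadable from compound 1 to compound 3.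

Compound 4 `O=C(O)c1cccc([C@H]2CC[C@]3(CC2)OOC2(O3)C3CC4CC(C3)CC2C4)c1` is not yet measured. It differs from compound 3 by 3-carboxyphenyl in place of 4-carboxyphenyl on a saturated ring carbon. Among the measured compounds shown here, none of the measured steps moves a group around the aromatic ring; each swaps one group for another, so none bears directly on this change, and no step beyond the scatter is expected in this assay. The expected step is an at least 1.2-fold higher number from compound 3 to compound 4 (0.09 log units; that floor lies within the scatter). Compound 4 is therefore estimated at 2 ug/mL, within 0.8 ug/mL to 6 ug/mL, with a fair chance that only a limit is reported.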

Compound 4, solubility: < 1.6 ug/mL
Compound 4 gave a limit, no number; the forecaster's own chance of this, stated with the estimate: 50%; middle value at least 1.2-fold (0.09 log units) from the limit.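

Compound 3 and compound 4 each gave only a limit, not a number, in this assay, so the step between them cannot be read: the limit of < 1.6 ug/mL in this assay, at which 2 of the 4 values shown sit.

The compounds shown leave open whether 3-carboxyphenyl and 4-carboxyphenyl differ at all in this assay.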